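The source may hold more compounds than are shown below. What is called first, only, known or untested is meant among the compounds shown, and "the series" means these compounds.

In an ADME assay on HEK293 cells (Homo sapiens) for cytotoxicity, read by CCK-8 assay, with a stated time of 48 h (on this read-out lower numbers stand for stronger inhibition and higher numbers for weaker inhibition), three compounds sharing one core have been measured, and each result is a limit, not a number. Compound 1 `COc1ccc(/C=C\c2cc(OC)c(OC)c(OC)c2)cc1OCc1ccc(CN2CCCCC2C(=O)O)cc1` gives the limit > 50000 nM. Compound 2 `COc1ccc(/C=C\c2cc(OC)c(OC)c(OC)c2)cc1OCc1ccc(CN[C@H](C(=O)O)[C@H](C)O)cc1` gives the limit > 50000 nM. Compound 3 `COc1ccc(/C=C\c2cc(OC)c(OC)c(OC)c2)cc1OCc1ccc(CN2CC(C(=O)O)C2)cc1` gives the limit > 50000 nM. All three thus sit at the limit of > 50000 nM in this assay, at which 3 of the 3 values shown sit. Compound 4 `COc1ccc(/C=C\c2cc(OC)c(OC)c(OC)c2)cc1OCc1ccc(CN2CC[C@@H](C(=O)O)C2)cc1` differs from compound 3 in one group, on a saturated chain carbon bound to an aromatic carbon: 3-carboxypyrrolidin-1-yl in place of 3-carboxyazetidin-1-yl on a saturated chain carbon bound to an aromatic carbon. Two measured steps at this place bear on it: a step that the two limits leave unreadable from compound 1 to compound 3 and a step that the two limits leave unreadable from compound 2 to compound 3. With no readable size to draw on, no change beyond the scatter is expected in this assay, and the estimated step is a step that the limit leaves unreadable from compound 3 to compound 4. Compound 4 is expected at 60000 nM, with an estimated range of 40000 nM to 100000 nM.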

Compound 4, half-maximal inhibitory concentration: 27000 nM
Compound 4: middle estimate off by 2.2-fold (0.35 log units), on the high side, and the stated range ends above it.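

In this assay, within the data shown here, compound 4 gives 27000 nM, a measured number and not a limit, so 3-carboxypyrrolidin-1-yl on a saturated chain carbon bound to an aromatic carbon gives the first readable value at this place. The data give an at least 1.8-fold lower number from compound 3 to compound 4 (0.26 log units; that floor lies within the scatter), an at least 1.8-fold lower number from compound 2 to compound 4 (0.26 log units; that floor lies within the scatter) and an at least 1.8-fold lower number from compound 1 to compound 4 (0.26 log units; that floor lies within the scatter), so only a floor is known for each step. Compound 1, compound 2 and compound 3 each remain a limit, and the steps among them cannot be read: the limit of > 50000 nM in this assay, at which 3 of the 4 values shown sit.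

On these data alone, whether an ester in place of the carboxylic acid would change the number stays open. So does the effect of the opposite configuration at the defined stereocentre of 3-carboxypyrrolidin-1-yl.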